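Working notes: from compound 3 to compound 4

The compounds below may be only part of what the source reports. "The series", "measured", "known", "first", "only" and "open" are said of these compounds alone.

In a functional assay on A549 cells (Homo sapiens) for inhibition, read by MTT assay, with a stated time of 24 h (on this read-out higher numbers stand for weaker inhibition and lower numbers for stronger inhibition), compound 3 (`CC1(C)[C@H]2CC[C@]1(C)N(Cc1cn(-c3cccc(Cl)c3)nn1)C(=O)C2`) gives 60 nM, the lowest of the three numbers. Compound 2 (`CC1(C)[C@H]2CC[C@]1(C)N(Cc1cn(-c3ccccc3Br)nn1)C(=O)C2`) gives 130 nM, and compound 1 (`CC1(C)[C@H]2CC[C@]1(C)N(Cc1cn(-c3cccc(F)c3)nn1)C(=O)C2`) gives 180 nM. The next structure, compound 4 (`CC1(C)[C@H]2CC[C@]1(C)N(Cc1cn(-c3ccccc3O)nn1)C(=O)C2`), has 2-hydroxyphenyl in place of 3-chlorophenyl on an aromatic nitrogen.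

Two modest steps bear on this change: a 3.0-fold lower number from compound 1 to compound 3 (0.48 log units; beyond the scatter), and a 2.2-fold lower number from compound 2 to compound 3 (0.34 log units; beyond the scatter). Both end at the 3-chlorophenyl group, whereas a 1.4-fold lower number from compound 1 to compound 2 (0.14 log units; within the scatter) stays within the scatter. Within the data shown here, no measured compound carries a hydroxy group, so this precedent is indirect. A modest move to a higher number in this assay is expected, a 2.5-fold higher number from compound 3 to compound 4 (0.40 log units; beyond the scatter). The estimated value for compound 4 is 150 nM, within an expected range of 50 nM to 450 nM.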

Compound 4, half-maximal inhibitory concentration: 230 nM
For compound 4 the middle estimate is 1.5-fold (0.19 log units) below the measured one; low and high end bracket the measured number.
By their numbers in this assay, from the lowest: compound 3; then compounds 2, 1 and 4 (each within the scatter of the next).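

The 2-hydroxyphenyl group, the only one here with a hydrogen-bond donor, does not keep the lower number of the 3-chlorophenyl group (a 3.8-fold higher number from compound 3 to compound 4 (0.58 log units; beyond the scatter)). It does not separate from the two other groups (a 1.8-fold higher number from compound 2 to compound 4 (0.25 log units; within the scatter); a 1.3-fold higher number from compound 1 to compound 4 (0.11 log units; within the scatter)), so a hydroxy group is accepted on this ring with no clear difference from 2-bromophenyl or 3-fluorophenyl. No supporting data account for the gap to compound 3.

This step changes both the substituent and its ring position, leaving their contributions unseparated. From the compounds shown here alone, a 3-hydroxyphenyl or 2-chlorophenyl group would separate them, and an amine or a carboxylic acid on this ring remains open.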